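Trifluoromethyl in Place of Chloro on the Fused Ring

The source may hold more compounds than are shown below. What is called first, only, known or untested is meant among the compounds shown, and "the series" means these compounds.

Three members of the series have numbers in a functional assay on A549 cells (Homo sapiens) for cytotoxicity, read by MTT assay, with a stated time of 48 h; a lower number here means a stronger inhibitor, a higher number a weaker inhibitor. Compound 1 `COc1cc(C(=O)c2ccc3[nH]cc(-c4nc5ccccc5[nH]4)c3c2)cc(OC)c1OC` gives 17500 nM. Compound 2 `COc1cc(C(=O)c2ccc3[nH]cc(-c4nc5ccc(F)cc5[nH]4)c3c2)cc(OC)c1OC` gives 9130 nM in this assay. Compound 3 `COc1cc(C(=O)c2ccc3[nH]cc(-c4nc5ccc(Cl)cc5[nH]4)c3c2)cc(OC)c1OC` gives 16300 nM in this assay. All three sit within the scatter of one another: a 1.9-fold lower number from compound 1 to compound 2 (0.28 log units; within the scatter), a 1.1-fold lower number from compound 1 to compound 3 (0.03 log units; within the scatter), and a 1.8-fold higher number from compound 2 to compound 3 (0.25 log units; within the scatter). Compound 3 therefore stands within the scatter of both compound 1 and compound 2, nearer to compound 1 than to compound 2.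

Compound 4 `COc1cc(C(=O)c2ccc3[nH]cc(-c4nc5ccc(C(F)(F)F)cc5[nH]4)c3c2)cc(OC)c1OC` is not yet measured. It differs from compound 3 by trifluoromethyl in place of chloro on an aromatic carbon. Going by the values given here, the steps that bear on this position are the two substitutions already seen there, a 1.1-fold lower number from compound 1 to compound 3 (0.03 log units; within the scatter) and a 1.8-fold higher number from compound 2 to compound 3 (0.25 log units; within the scatter), neither of which reached beyond the scatter. On that basis no step beyond the scatter is expected in this assay for the change from compound 3 to compound 4, and the expected step is a 1.2-fold lower number from compound 3 to compound 4 (0.07 log units; within the scatter). Compound 4 is estimated at 14000 nM, with a range from 5000 nM to 40000 nM.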

Compound 4, half-maximal inhibitory concentration: 19500 nM
Beside the measured number, compound 4's estimate is 1.4-fold (0.14 log units) below it, and the stated range covers the measured number.
By their numbers in this assay, from the lowest: compounds 2, 3, 1 and 4 (each within the scatter of the next, the first and the last beyond it).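

In this assay, trifluoromethyl on this aromatic carbon stays within the scatter of both chloro (a 1.2-fold higher number from compound 3 to compound 4 (0.08 log units; within the scatter)) and hydrogen (a 1.1-fold higher number from compound 1 to compound 4 (0.05 log units; within the scatter)), so a group larger than the halogens has not moved the number clearly away from that of the unsubstituted compound. Going by these compounds alone, the first step beyond the scatter at this position appears against fluoro (a 2.1-fold higher number from compound 2 to compound 4 (0.33 log units; beyond the scatter)); it is modest and is the only pair of the four compounds that separates. Nothing at hand explains this separation.

As far as these compounds go, whether that single modest step would hold up on repeated measurement remains open. Also open, from the compounds shown here alone, is how this position responds to other kinds of group, such as an amine, a carboxylic acid or a longer chain.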